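The source may report more compounds than this note shows. Statements on the series, on what has been measured and on what is new or still open speak of the compounds shown alone.

Of the compounds shown here, two built on a shared core have been measured. For the measured compounds named here, compound 1 `NC(=O)c1c(NC(=O)c2ccccc2Cl)sc2c1CCN(Cc1ccc([N+](=O)[O-])cc1)C2` and compound 2 `NC(=O)c1c(NC(=O)c2ccccc2F)sc2c1CCN(Cc1c(Cl)cccc1Cl)C2` differ from each other in two places at once, so no single step connects them. In a functional assay on HL-60 cells (Homo sapiens) for antiproliferative activity, with a stated time of 24 h (a higher number here means a weaker inhibitor, a lower number a stronger inhibitor), compound 1 gives 11400 nM, and in this assay compound 2 gives 10300 nM. Compound 1 carries the highest of the two numbers, but its gap to compound 2 lies within the scatter, so the two values show no real difference between them.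

Compound 3 `NC(=O)c1c(NC(=O)c2ccccc2Cl)sc2c1CCN(C(=S)Nc1ccccc1F)C2` is derived from compound 1 by one change, namely (a group of 10 heavy atoms (7 carbon, 1 nitrogen, 1 fluorine, 1 sulfur; one six-membered aromatic ring of carbon only) in place of a group of 10 heavy atoms (7 carbon, 1 nitrogen, 2 oxygen; one six-membered aromatic ring of carbon only), on an amine nitrogen in a ring). Going by the values given here, no pair of measured compounds has yet been compared along a single change, so there is no measured step from which to read what such a swap does here. The expectation for compound 3 therefore rests on compound 1 alone, and the expected step is a 1.1-fold lower number from compound 1 to compound 3 (0.06 log units; within the scatter), which amounts to nothing beyond the scatter. For compound 3 in this assay the estimated value is 10000 nM, within a range from 3000 nM to 35000 nM.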

Compound 3, half-maximal inhibitory concentration: 4970 nM
For compound 3 the middle estimate is 2.0-fold (0.30 log units) above the measured one, within the range that was stated.
By their numbers in this assay, from the lowest: compound 3; then compounds 2 and 1 (each within the scatter of the next).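

For the compounds shown here, replacing the 4-nitrobenzyl group on the amine nitrogen in the ring with the fluorine- and sulfur-bearing group gives a 2.3-fold lower number from compound 1 to compound 3 (0.36 log units; beyond the scatter) in this assay, the first single-change comparison in this set and evidence that what sits at this position can alter the read-out, if only modestly. The two groups match in several counted features: each has 10 heavy atoms, one six-membered aromatic ring of carbon only and one double bond outside aromatic rings, so the step cannot be tied to any of these counts. They differ in their atoms and in their hydrogen-bond counts, with the entering group having 1 donor and 1 acceptor against 0 donors and 2 acceptors for the leaving group, but no measurement here gives a reason for the step.

Because the atoms and hydrogen-bond counts all change in a single swap, the compounds shown cannot separate the contribution of the sulfur, the fluorine or the donor hydrogen. As far as these compounds go, it also remains open how this position would respond to a plain benzyl group, an amine or a carboxylic acid on a longer chain.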